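Removing the acetyl-bearing pyrazole: what compound 4 may show

This account rests on a few compounds, and the source may have more. Where it says the series, first, only, none or still open, it means among the compounds named here.

Measured compounds:
compound 1 `CNC(=O)N1CCCc2ccc(NC(=O)c3cccc(-c4ccn(C)n4)c3)cc21` gives 99.5%
compound 2 `CNC(=O)N1CCCc2ccc(NC(=O)c3cccc(-c4cn[nH]c4)c3)cc21` gives 77.7%
compound 3 `CNC(=O)N1CCCc2ccc(NC(=O)c3ccc(-c4ccn(C(C)=O)n4)cc3)cc21` gives 91.4%

In a functional assay on MV4-11 cells (Homo sapiens) for antiproliferative activity, with a stated time of 6 days, tested at 6.25 uM (on this read-out lower numbers stand for a weaker effect and higher numbers for a stronger effect at the one concentration tested), compound 3 stands second of the three, close to compound 1 within the scatter and clearly ahead of compound 2. Compound 4 `CNC(=O)N1CCCc2ccc(NC(=O)c3ccc(-c4cn[nH]c4)cc3)cc21` differs from compound 3 in one place: 1H-pyrazol-4-yl in place of 1-acetyl-1H-pyrazol-3-yl on an aromatic carbon. For the measured compounds named here, the one measured step that resembles this change is a number 21.8 percentage points lower from compound 1 to compound 2 (beyond the scatter), where a substituted pyrazole was likewise replaced by the unsubstituted 1H-pyrazol-4-yl, though attached at a different site of the shared core. A decrease of similar size, beyond the scatter, is therefore expected for compound 4, namely a number 19.4 percentage points lower from compound 3 to compound 4 (beyond the scatter). Compound 4 is estimated at 72%, within a range from 50% to 90%.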

Compound 4, a percentage reported as inhibition, at one concentration (the size of the read-out at that concentration, not a potency): 98.3%
Estimate against measurement, compound 4: 26.3 percentage points below; measured number above the stated range.
By their numbers in this assay, from the lowest: compound 2; then compounds 3, 4 and 1 (each within the scatter of the next).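

At the place para to a large group, 1H-pyrazol-4-yl takes over from 1-acetyl-1H-pyrazol-3-yl with no clear change in this assay, a number 6.9 percentage points higher from compound 3 to compound 4 (within the scatter). The ring carrying no acetyl therefore keeps the effect here, so the fall seen elsewhere on the shared core, a number 21.8 percentage points lower from compound 1 to compound 2 (beyond the scatter), does not carry over to this position. Nothing available explains why the two steps differ.

Still open, as far as these compounds go, is whether a simple amine or a carboxylic acid at this place would keep the effect. From the compounds shown here alone, because each number comes from one concentration, potency also remains unknown.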